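The compounds below may be only part of what the source reports. "The series", "measured", "known", "first", "only" and "open" are said of these compounds alone.

In an assay for inhibition of cytokinin dehydrogenase 2 (Arabidopsis thaliana) (on this read-out higher numbers stand for weaker inhibition and lower numbers for stronger inhibition), two compounds of a shared core have been measured. Compound 1, `COc1cccc(Nc2nc(Cl)nc3[nH]cnc23)c1`, gives 1900 nM. Compound 2, `COc1cccc(Nc2nc(F)nc3[nH]cnc23)c1`, gives 1000 nM. Within the data shown here, the only measured step, a 1.9-fold lower number from compound 1 to compound 2 (0.28 log units; within the scatter), stays inside the usual scatter, so the two numbers cannot be told apart with confidence, and compound 2 stands at a value that differs from compound 1 by no more than repeated measurement would. Compound 3, `COc1cccc(Nc2nc(N)nc3[nH]cnc23)c1`, is not yet measured. It differs from compound 2 by amino in place of fluoro on an aromatic carbon. Among the measured compounds shown here, no measured step bears on this particular exchange: the one known step swaps one halogen for another, whereas here the halogen is replaced by an amino group, which brings a hydrogen-bond donor and acceptor where none stood before. With nothing comparable on record, the size and direction of the step in this assay are open, and the expectation is built around the value of compound 2 with a wide range. The expected step of no change at the digits printed from compound 2 to compound 3 (within the scatter) is therefore set at no change beyond the scatter. Compound 3 is expected to give 1000 nM, within a range from 200 nM to 5000 nM.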

Compound 3, half-maximal inhibitory concentration: 27000 nM
For compound 3 the middle estimate is 27-fold (1.43 log units) below the measured one; the measured number lies above the stated range.
By their numbers in this assay, from the lowest: compounds 2 and 1 (each within the scatter of the next); then compound 3.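

In this assay, this position proves sensitive to what stands on it: the two halogens could not be told apart, yet amino in place of fluoro gives a 27-fold higher number from compound 2 to compound 3 (1.43 log units; beyond the scatter), and amino in place of chloro gives a 14-fold higher number from compound 1 to compound 3 (1.15 log units; beyond the scatter), both towards weaker inhibition and both beyond the scatter. The earlier pair showed only that one halogen can take the place of the other on this aromatic carbon between two ring nitrogen atoms, whereas the new compound shows that the position does not accept every small group, even though amino and fluoro count the same number of heavy atoms and the exchange adds only a hydrogen-bond donor and acceptor. No measurement is available that explains the loss, so its origin remains unknown.

On these data alone, whether the loss belongs to amino alone or extends to other groups on this carbon, such as methylamino, dimethylamino, hydroxyl, methoxy or methyl, stays open. Also open, as far as these compounds go, is whether any group here would give a clearly lower number than the two halogens do.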